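The source may hold more compounds than are shown below. What is called first, only, known or untested is meant among the compounds shown, and "the series" means these compounds.

Compound 1, `CCCCCCc1cn([C@H]2C[C@@H]3OP(=O)(O)OC[C@H]3O2)c(=O)[nH]c1=O`, in a functional assay on L1210 cells (Mus musculus) (on this read-out higher numbers stand for weaker inhibition and lower numbers for stronger inhibition), gives > 500 ug/mL, a limit of the assay.
Compound 2, `CCCc1cn([C@H]2C[C@@H]3OP(=O)(O)OC[C@H]3O2)c(=O)[nH]c1=O`, in this assay gives > 500 ug/mL, again only a limit.
Compound 3, `CCCCCc1cn([C@H]2C[C@H](O)[C@@H](CO)O2)c(=O)[nH]c1=O`, in this assay gives 476 ug/mL.

Compound 2 therefore stands at the limit of this assay rather than at a number, and it shares that position with the limit of > 500 ug/mL in this assay, at which 2 of the 3 values shown sit. Compound 4, `CCCCc1cn([C@H]2C[C@@H]3OP(=O)(O)OC[C@H]3O2)c(=O)[nH]c1=O`, differs from compound 2 by methyl in place of hydrogen on a saturated chain carbon, three bonds along the chain from an aromatic carbon. Going by the values given here, the only measured step on a related change is a step that the two limits leave unreadable from compound 1 to compound 2, whose size the two limits leave unreadable. No readable step therefore bears on the change from compound 2 to compound 4, and compound 4 is expected to remain at the limit, a step of a number no higher from compound 2 to compound 4 (the limit leaves the size open). The estimate for compound 4 in this assay is 500 ug/mL, within 300 ug/mL to 1200 ug/mL.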

Compound 4, concentration for 50% inhibition: 28.4 ug/mL
Compound 4: the middle estimate sits 18-fold (1.25 log units) above what was measured, outside the stated range (below it).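

On the shared core, this position is sensitive to chain length: going from propyl to butyl in this assay gives an at least 17-fold lower number from compound 2 to compound 4 (1.24 log units; beyond the scatter). Shortening hexyl to butyl also gives an at least 17-fold lower number from compound 1 to compound 4 (1.24 log units; beyond the scatter), so the number does not move in one direction as the chain grows. Compound 1 and compound 2 each remain at a limit rather than a number: the limit of > 500 ug/mL in this assay, at which 2 of the 4 values shown sit.

The limits leave the step between compound 1 and compound 2 unreadable. Also open, from the compounds shown here alone, is whether a pentyl chain on this core matches butyl, and how an amine at this place would read.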